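From Thiophene to Fluorophenyl on a Shared Sulfonamide Core

This account rests on a few compounds, and the source may have more. Where it says the series, first, only, none or still open, it means among the compounds named here.

Compound 3 `O=S(=O)(Nc1ccc2oc(-c3ccccc3)nc2c1)c1cccs1` was tested in an assay on isolated protein for inhibition of malate dehydrogenase, mitochondrial (Sus scrofa), with stated times of 45 min and 30 min; on this read-out lower numbers stand for stronger inhibition and higher numbers for weaker inhibition. In this assay compound 3 reaches only the limit > 63000 nM, so no number is known for it. Two related compounds share that fate. Compound 1 `O=S(=O)(Nc1ccc(-c2nc3ccccc3o2)cc1)c1cccs1` also gives only the limit > 63000 nM. Compound 2 `C=Cc1ccc(S(=O)(=O)Nc2ccc(-c3nc4ccccc4o3)cc2)cc1` likewise stops at the limit > 63000 nM. Going by the values given here, the single step between measured compounds, a step that the two limits leave unreadable from compound 1 to compound 2, therefore cannot be read, and the limit of > 63000 nM in this assay, at which 3 of the 3 values shown sit, sums up the whole picture: every value shown is a limit.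

Compound 4 `O=S(=O)(Nc1ccc2oc(-c3ccccc3)nc2c1)c1cccc(F)c1` is not yet measured. It differs from compound 3 by 3-fluorophenyl in place of thiophen-2-yl on a sulfonyl sulfur. This change resembles the move from compound 1 to compound 2 only loosely, since 4-vinylphenyl enters there, and that step gave no readable size. Among the compounds with values here, no measured step therefore speaks for a gain in inhibition here, and the expectation is that placing 3-fluorophenyl on the sulfonyl sulfur leaves the outcome where compound 3 stands. The expected step that the limit leaves unreadable from compound 3 to compound 4 is thus none beyond the scatter, most likely ending again at the limit. Compound 4 is estimated at 100000 nM in this assay, with a range from 30000 nM to 400000 nM.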

Compound 4, half-maximal inhibitory concentration: > 63000 nM
Compound 4 was reported as a limit (the forecaster's own chance of this, stated with the estimate: 85%); the middle value is on the limit's open side.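

Going by these compounds alone, compound 3 and compound 4 both stop at a limit in this assay, so placing 3-fluorophenyl where thiophen-2-yl stood gives no step that can be read. The compounds shown leave open whether any of them inhibits measurably, and how strongly, since all four give only a limit and no number: the limit of > 63000 nM in this assay, at which 4 of the 4 values shown sit.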